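From a cyanocyclobutyl to an oxadiazolyl cyclopropyl group

The compounds below may be only part of what the source reports. "The series", "measured", "known", "first", "only" and "open" are said of these compounds alone.

In an ADME assay on MDCKII-LE cells (Canis lupus familiaris) for permeability (on this read-out lower numbers stand for lower permeability and higher numbers for higher permeability), compound 2 (`N#C[C@H]1C[C@H](CN([C@H](CCC(F)(F)F)C(N)=O)S(=O)(=O)c2ccc(Cl)cc2)C1`) gives 24.9 10^-6 cm/s and stands above compound 1 (`N#CCCN([C@H](CCC(F)(F)F)C(N)=O)S(=O)(=O)c1ccc(Cl)cc1`) with 10.2 10^-6 cm/s on the same scale. Compound 3 (`N#C[C@H]1CC[C@H](CN([C@H](CCC(F)(F)F)C(N)=O)S(=O)(=O)c2ccc(Cl)cc2)CC1`) reads 15.7 10^-6 cm/s; 14.6 10^-6 cm/s (2 entries) here, and the several entries of compound 3 in this assay, 15.7 10^-6 cm/s; 14.6 10^-6 cm/s (2 entries) show how closely repeats can agree.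

The next compound to be tested is compound 4 (`NC(=O)[C@@H](CCC(F)(F)F)N(CC1(c2ncon2)CC1)S(=O)(=O)c1ccc(Cl)cc1`). It carries 1-(1,2,4-oxadiazol-3-yl)cyclopropyl in place of 3-cyanocyclobutyl on a saturated chain carbon bound to a sulfonamide nitrogen. Going by the values given here, no measured step makes this exact swap. The nearest evidence is a 2.4-fold higher number from compound 1 to compound 2 (0.39 log units; beyond the scatter) at the same place, a modest move that shows a new group there can shift the reading. A new group could land nearer compound 1 at 10.2 10^-6 cm/s as readily as stay near compound 2 at 24.9 10^-6 cm/s on this scale. A small move toward lower numbers in this assay is therefore expected, no larger than that one measured step. The estimate means a 1.8-fold lower number from compound 2 to compound 4 (0.25 log units; within the scatter) and no clear drop. For compound 4 the estimated value is 14 10^-6 cm/s with an expected range from 6 10^-6 cm/s to 30 10^-6 cm/s in all.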

Compound 4, apparent permeability: 16.4 10^-6 cm/s
For compound 4 the middle estimate is 1.2-fold (0.07 log units) below the measured one; low and high end bracket the measured number.
By their numbers in this assay, from the lowest: compounds 1, 4 and 2 (each within the scatter of the next, the first and the last beyond it).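

Going by these compounds alone, compounds 1, 2 and 3 all carry a nitrile, so compound 4 gives the first reading here, on a saturated chain carbon bound to a sulfonamide nitrogen, for a group without one. In this assay the swap to 1-(1,2,4-oxadiazol-3-yl)cyclopropyl, which brings 8 heavy atoms and an aromatic ring, gives a 1.5-fold lower number from compound 2 to compound 4 (0.18 log units; within the scatter) and, set against cyanomethyl, a 1.6-fold higher number from compound 1 to compound 4 (0.21 log units; within the scatter), so the nitrile is not needed for a reading in this range. Compounds 1 and 2 remain clearly apart, with a 2.4-fold higher number from compound 1 to compound 2 (0.39 log units; beyond the scatter) as their step, while compound 4 cannot be ranked against either, and repeat readings of a single compound give a sense of how near two entries can fall: the several entries of compound 3 in this assay, 15.7 10^-6 cm/s; 14.6 10^-6 cm/s (2 entries).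

Both rings change in one step, so the compounds shown cannot separate what the cyclopropyl contributes from what the 1,2,4-oxadiazol-3-yl ring contributes. As far as these compounds go, how an amine, a carboxylic acid or a longer plain carbon chain would read at this place also remains open.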